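Allyloxy in Place of Allyl on Compound 1

This account rests on a few compounds, and the source may have more. Where it says the series, first, only, none or still open, it means among the compounds named here.

In a functional assay on SK-MEL-28 cells (Homo sapiens) for inhibition, read by colorimetric assay and MTT assay, with a stated time of 72 h (a lower number here means a stronger inhibitor, a higher number a weaker inhibitor), compound 1 `C=CCCCCOc1ccccc1-c1cnc(OCCCC=C)n1C` gives 19000 nM. In this assay, compound 3 `C=CCCCCOc1ncc(-c2cc(C(F)(F)F)ccc2OC)n1C` gives 56000 nM, and compound 2 `CCCCOc1ncc(-c2ccccc2OC)n1C` gives 82000 nM. Compound 1 therefore has the lowest number of the three, and its gaps to both others lie beyond the usual scatter of repeated measurements.

Compound 4 `C=CCCCCOc1ccccc1-c1cnc(OCCOCC=C)n1C` has not yet been measured. It keeps the core of compound 1 and changes one group: allyloxy in place of allyl on a saturated chain carbon, two bonds along the chain from an oxygen on an aromatic ring. That is allyloxy in place of allyl on a saturated chain carbon, two bonds along the chain from an oxygen on an aromatic ring.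

Within the data shown here, no two measured compounds differ in one place only, so the data do not show directly what this kind of change does. The measured range, from compound 1 at 19000 nM to compound 2 at 82000 nM, offers only a loose guide. The expected size is a 1.6-fold higher number from compound 1 to compound 4 (0.20 log units; within the scatter), a small move towards a weaker number that may stay within the scatter. For compound 4 the estimated value in this assay is 30000 nM, with an expected range from 14000 nM to 70000 nM.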

Compound 4, half-maximal inhibitory concentration: 59000 nM
The estimate for compound 4 lay 2.0-fold (0.29 log units) below the measured number; the range from low to high includes it.
By their numbers in this assay, from the lowest: compound 1; then compounds 3, 4 and 2 (each within the scatter of the next).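

In this assay putting allyloxy in place of allyl on a saturated chain carbon, two bonds along the chain from an oxygen on an aromatic ring, gives a 3.1-fold higher number from compound 1 to compound 4 (0.49 log units; beyond the scatter) and so clears the usual scatter. Among these compounds, this is the first comparison here in which only one place differs, and it shows that this chain position responds to the change: going from (pent-4-en-1-yl)oxy to 2-(allyloxy)ethoxy brings in an oxygen and moves the number towards weaker inhibition. Nothing available explains why the number rises. Open still is whether the oxygen within the chain matters in itself or whether a longer all-carbon chain would give a similar step. An amine in the same place would also test whether other atoms there give a step of this kind.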